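The source may hold more compounds than are shown below. What is called first, only, known or untested is meant among the compounds shown, and "the series" means these compounds.

Compound 3 `Cc1nn(-c2ncnc3nc[nH]c23)c2c1C(OC(=O)c1ccc(F)cc1)CC(=O)N2` gives 4 nM in a functional assay on HEK293 cells for agonist activity at G-protein coupled receptor 39 (Homo sapiens), read by scintillation proximity assay and inositol phosphate accumulation, with a stated time of 75 min, in the presence of a further agent that is not named here (on this read-out lower numbers stand for an effect already at smaller amounts and higher numbers for an effect only at larger amounts of compound), the second highest of the three numbers. Compound 2 `Cc1nn(-c2ncnc3nc[nH]c23)c2c1C(NC(=O)Cc1cccs1)CC(=O)N2` gives 3 nM in this assay, and the pair lies within the scatter: a 1.3-fold higher number from compound 2 to compound 3 (0.12 log units; within the scatter). Compound 1 `Cc1cc(C)n(CCOC2CC(=O)Nc3c2c(C)nn3-c2ncnc3nc[nH]c23)n1` gives 16 nM in this assay, so the step to compound 3 was a 4.0-fold lower number from compound 1 to compound 3 (0.60 log units; beyond the scatter) and to compound 2 a 5.3-fold lower number from compound 1 to compound 2 (0.73 log units; beyond the scatter). Compound 4 `Cc1nn(-c2ncnc3nc[nH]c23)c2c1C(OCCc1ccccc1)CC(=O)N2` carries phenethyl in place of (4-fluorophenyl)carbonyl on an oxygen on a saturated carbon. The two-carbon chain on the oxygen is shared with compound 1, whose number was higher; the carbonyl of compound 3 is gone. A modest rise, smaller than the step from compound 1, is therefore expected: a 2.3-fold higher number from compound 3 to compound 4 (0.35 log units; beyond the scatter). Compound 4 is estimated at 9 nM in this assay, between 3 nM and 27 nM.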

Compound 4, half-maximal effective concentration: 3 nM
For compound 4 the middle estimate is 3.0-fold (0.48 log units) above the measured one, within the range that was stated.
By their numbers in this assay, from the lowest: compounds 2, 4 and 3 (each within the scatter of the next); then compound 1.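

At this position the carbonyl is not required: a 1.3-fold lower number from compound 3 to compound 4 (0.12 log units; within the scatter) is seen when phenethyl stands on the oxygen, and no change at the digits printed from compound 2 to compound 4 (within the scatter) is seen with phenethyloxy on the saturated ring carbon. With the oxygen and chain kept, a 5.3-fold lower number from compound 1 to compound 4 (0.73 log units; beyond the scatter) follows from phenyl in place of 3,5-dimethyl-1H-pyrazol-1-yl, which places the difference on the ring carried by the chain. No evidence at hand explains these steps.

Still open, from the compounds shown here alone, is how a longer chain, or an amine or carboxylic acid on the phenyl ring of phenethyl, would read.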